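Working notes: from piperidine chain to compound 3

The source may hold more compounds than are shown below. What is called first, only, known or untested is meant among the compounds shown, and "the series" means these compounds.

Compound 1 `COc1cc(OC)c2c(=O)c(OCC(=O)N/N=C/c3ccc(C)cc3)c(-c3cc(OC)c(OC)c(OC)c3)oc2c1`: 3510 nM
Compound 2 `COc1cc(OC)c2c(=O)c(OCCCCN3CCCCC3)c(-c3cc(OC)c(OC)c(OC)c3)oc2c1`: 26800 nM

In a functional assay on MGC-803 cells (Homo sapiens) for cytotoxicity, read by MTT assay, with a stated time of 38 h (on this read-out higher numbers stand for weaker inhibition and lower numbers for stronger inhibition), compound 2 gives the higher number of the two, 26800 nM, so it is the weaker inhibitor of this pair. Compound 3 `COc1cc(OC)c2c(=O)c(OCC(=O)N/N=C/c3ccc[nH]3)c(-c3cc(OC)c(OC)c(OC)c3)oc2c1` has not yet been measured. Its change from compound 2 is a group of 10 heavy atoms (6 carbon, 3 nitrogen, 1 oxygen; one five-membered aromatic ring with 1 hetero atom) in place of a group of 9 heavy atoms (8 carbon, 1 nitrogen; one six-membered non-aromatic ring with 1 hetero atom), on a saturated chain carbon bound to an oxygen on an aromatic ring. The 3-(piperidin-1-yl)propyl group leaves, and a group with a five-membered aromatic ring enters.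

Within the data shown here, only one measured step bears on this: a 7.6-fold higher number from compound 1 to compound 2 (0.88 log units; beyond the scatter). Among the measured compounds shown here, that step is modest but beyond the scatter, and it is the sole guide here. The entering group resembles the group of compound 1 more than the one leaving, since both hold an aromatic ring. A step of similar size towards a lower number is therefore expected in this assay: a 6.7-fold lower number from compound 2 to compound 3 (0.83 log units; beyond the scatter). For compound 3 the estimated value is 4000 nM, with an expected range from 1300 nM to 12000 nM.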

Compound 3, half-maximal inhibitory concentration: 5610 nM
Compound 3: the middle estimate sits 1.4-fold (0.15 log units) below what was measured, and the stated range covers the measured number.
By their numbers in this assay, from the lowest: compounds 1 and 3 (each within the scatter of the next); then compound 2.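

In this assay, the group entering in place of 3-(piperidin-1-yl)propyl, on a saturated chain carbon bound to an oxygen on an aromatic ring, gives a 4.8-fold lower number from compound 2 to compound 3 (0.68 log units; beyond the scatter), so a second group with an aromatic ring, this one five-membered, also stands apart from the piperidine compound. With 1H-pyrrol-2-yl in place of 4-methylphenyl on a carbon with a double bond to nitrogen, the step is a 1.6-fold higher number from compound 1 to compound 3 (0.20 log units; within the scatter), and these two aromatic groups cannot be told apart in this assay. No measurement at hand accounts for either step.

The entering and leaving groups differ in both chain and ring, and the compounds shown do not separate the two. As far as these compounds go, how a pyridin-2-yl group on that same carbon would read, or a morpholine ring in place of the piperidine ring, remains open.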